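This account rests on a few compounds, and the source may have more. Where it says the series, first, only, none or still open, it means among the compounds named here.

Of the compounds shown here, three sharing one core have been tested in a functional assay on H184B5F5/M10 cells (Homo sapiens) for antiproliferative activity, read by MTT assay, with a stated time of 24 h; a higher number here means a weaker inhibitor, a lower number a stronger inhibitor. Compound 1 `COc1ccc(C(=O)NNC(=O)/C=C/c2ccc(O)cc2)cc1` gives 8440 nM in this assay. Compound 2 `O=C(/C=C/c1ccc(O)cc1)NNC(=O)c1ccc(O)cc1` differs from compound 1 by hydrogen in place of methyl on an oxygen on an aromatic ring. In this assay compound 2 reaches only a limit, > 10000 nM, which is the limit of > 10000 nM in this assay, at which 1 of the 3 values shown sits. That change made an at least 1.1-fold higher number from compound 1 to compound 2 (0.07 log units; that floor lies within the scatter). Compound 3 `COc1cc(/C=C/C(=O)NNC(=O)c2ccccc2)ccc1O` has the same atoms as compound 1 joined differently, and the difference between the two cores is not broken down here. In this assay compound 3 gives 9170 nM.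

Compound 4 `O=C(/C=C/c1ccc(O)c(O)c1)NNC(=O)c1ccccc1` is not yet measured in this assay. It differs from compound 3 by hydrogen in place of methyl on an oxygen on an aromatic ring, the same change as that made from compound 1 to compound 2, at a place described in the same words. The earlier change an at least 1.1-fold higher number from compound 1 to compound 2 (0.07 log units; that floor lies within the scatter) pushed the value to a limit, so a weaker inhibitor, possibly again reported only as a limit, is expected here. The expected step is a 1.3-fold higher number from compound 3 to compound 4 (0.12 log units; within the scatter). Compound 4 is expected to give 12000 nM in this assay, with a likely range from 6000 nM to 25000 nM.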

Compound 4, half-maximal inhibitory concentration: 8120 nM
Beside the measured number, compound 4's estimate is 1.5-fold (0.17 log units) above it; measured number inside the range.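

On the second core, the change from methoxy to hydroxy gives a 1.1-fold lower number from compound 3 to compound 4 (0.05 log units; within the scatter) in this assay, so a swap that might have been expected to weaken the compound produces no readable shift here. Set beside the same change on the first core, the result can be compared only loosely: the same change on two cores in this assay, an at least 1.1-fold higher number (0.07 log units; that floor lies within the scatter) from compound 1 to compound 2 and a 1.1-fold lower number (0.05 log units; within the scatter) from compound 3 to compound 4; the limit leaves it open whether they differ. In that earlier pair, the > 10000 nM of compound 2 is a limit and not a number, so the two steps show neither that the change carries over from one core to the other nor that it fails to.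

The compounds shown leave open whether a different group on this oxygen, such as an ethyl group or a longer chain, or an amine in place of the oxygen, would move the number beyond the scatter. As far as these compounds go, it also remains open how this change would read on a core whose values lie well clear of the limit.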